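This account rests on a few compounds, and the source may have more. Where it says the series, first, only, none or still open, it means among the compounds named here.

Compound 3 `Cc1ccc(CNC(=O)c2nc(-c3ccc(F)cc3)n(CC[C@@H](O)C[C@@H](O)CC(=O)O)c2C2CC2)cc1` stands second highest of the three numbers in an assay on microsomes from liver for inhibition of 3-hydroxy-3-methylglutaryl-coenzyme A reductase (Rattus norvegicus), read by scintillation counting, with stated times of 0.5 h and 0.75 h (on this read-out higher numbers stand for weaker inhibition and lower numbers for stronger inhibition), where compound 3 gives 1.7 nM. Its nearest neighbour is compound 2 `O=C(O)C[C@H](O)C[C@H](O)CCn1c(-c2ccc(F)cc2)nc(C(=O)NCc2ccccc2F)c1C1CC1`, which in this assay gives 1.5 nM, and the step of a 1.1-fold higher number from compound 2 to compound 3 (0.05 log units; within the scatter) lies within the scatter. The furthest is compound 1 `Cc1ccccc1CNC(=O)c1nc(-c2ccc(F)cc2)n(CC[C@@H](O)C[C@@H](O)CC(=O)O)c1C1CC1`, which in this assay gives 4.9 nM, so that a 2.9-fold lower number from compound 1 to compound 3 (0.46 log units; beyond the scatter). The change to compound 4 `O=C(O)C[C@H](O)C[C@H](O)CCn1c(-c2ccc(F)cc2)nc(C(=O)NCc2cccc(F)c2)c1C1CC1` is 3-fluorophenyl in place of 4-methylphenyl on a saturated chain carbon bound to an amide-type nitrogen. Among the measured compounds shown here, two measured steps bear on it: a 3.3-fold lower number from compound 1 to compound 2 (0.51 log units; beyond the scatter) shows that a fluoro in place of methyl on an aromatic carbon gave a lower number, whereas a 1.1-fold higher number from compound 2 to compound 3 (0.05 log units; within the scatter) shows that a fluorophenyl and a methylphenyl on this carbon sat within the scatter of each other. The second comparison is the closer one, so the expected step to compound 4 is a 1.1-fold higher number from compound 3 to compound 4 (0.02 log units; within the scatter), not beyond the scatter. Compound 4 is therefore estimated at 1.8 nM in this assay, with a range from 0.9 nM to 3.6 nM.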

Compound 4, half-maximal inhibitory concentration: 1.2 nM
The estimate for compound 4 lay 1.5-fold (0.18 log units) above the measured number, and the stated range covers the measured number.
By their numbers in this assay, from the lowest: compounds 4, 2 and 3 (each within the scatter of the next); then compound 1.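

The 3-fluorophenyl group on this saturated chain carbon bound to an amide-type nitrogen gives a number that cannot be told apart from those of its two closest relatives in this assay (a 1.4-fold lower number from compound 3 to compound 4 (0.15 log units; within the scatter)) and (a 1.3-fold lower number from compound 2 to compound 4 (0.10 log units; within the scatter)). A third fluorine-free or fluorine-bearing variant thus joins the same low group, so the low number is not tied to one substituent or one ring placement among these compounds. Only compound 1 stays apart (a 4.1-fold lower number from compound 1 to compound 4 (0.61 log units; beyond the scatter)), which leaves its 2-methylphenyl group as the sole outlier of the four.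

The compounds shown leave open how an unsubstituted phenyl, a 3-methylphenyl, a 4-fluorophenyl, or a ring bearing an amine or a carboxylic acid would read here. Nothing available explains the differences among these groups.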